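This account rests on a few compounds, and the source may have more. Where it says the series, first, only, none or still open, it means among the compounds named here.

Compound 1 `COc1ccc2[nH]c(-c3ccccc3)c(C(c3c(-c4ccccc4)[nH]c4ccc(Cl)cc34)C3C(=O)NN=C3C)c2c1` is the reference point of the series. In a functional assay on A549 cells (Homo sapiens) for cytotoxicity, read by MTT assay (a higher number here means a weaker inhibitor, a lower number a stronger inhibitor), compound 1 gives 1100 nM. Compound 2 `CC1=NNC(=O)C1C(c1c(-c2ccccc2)[nH]c2ccccc12)c1c(-c2ccccc2)[nH]c2ccc(Cl)cc12` carries the change hydrogen in place of methoxy on an aromatic carbon relative to compound 1, and in this assay compound 2 gives 31300 nM; the step of a 28-fold higher number from compound 1 to compound 2 (1.45 log units; beyond the scatter) is large. Compound 3 `COc1ccc2[nH]c(-c3ccccc3)c(C(c3c[nH]c4ccccc34)C3C(=O)NN=C3C)c2c1` has a different core from compound 1; the difference between the two cores is not broken down here. In this assay compound 3 gives 2700 nM, which sits between the other two values.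

Compound 4 `CC1=NNC(=O)C1C(c1c[nH]c2ccccc12)c1c(-c2ccccc2)[nH]c2ccccc12` has not yet been measured. It differs from compound 3 by hydrogen in place of methoxy on an aromatic carbon, the same change that separates compound 1 from compound 2, the place being the same in both cases. Among the measured compounds shown here, with only one earlier instance of this change, and that on a different core, the expected step of a 15-fold higher number from compound 3 to compound 4 (1.17 log units; beyond the scatter) is set near the earlier one, because of a 28-fold higher number from compound 1 to compound 2 (1.45 log units; beyond the scatter) seen on compound 1, but with wide uncertainty. Compound 4 is therefore estimated at 40000 nM, within a range from 8000 nM to 150000 nM.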

Compound 4, half-maximal inhibitory concentration: 5500 nM
Estimate against measurement, compound 4: 7.3-fold (0.86 log units) above, outside the stated range (below it).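

In this assay, hydrogen in place of methoxy on the aromatic carbon gives a 2.0-fold higher number from compound 3 to compound 4 (0.31 log units; beyond the scatter), a modest step in the same direction as the earlier one, but the size of the step does not carry over from one core to the other: the same change on two cores in this assay, a 28-fold higher number (1.45 log units; beyond the scatter) from compound 1 to compound 2 and a 2.0-fold higher number (0.31 log units; beyond the scatter) from compound 3 to compound 4, 14-fold (1.15 log units) apart, beyond the scatter of two such steps. The direction is shared by both pairs, and neither goes against it, so on these two cores the compound with methoxy gives the lower number; two pairs are too few to make this a rule for the series. The data do not show which difference between the core of compound 1 and the core of compound 3 sets the size of the step, as those cores differ in more than one place.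

The compounds shown leave open how another group at this place, such as an amine, a hydroxyl or a carboxylic acid, would read on either core. They also leave open whether the same change on a third core would lie nearer the large step or the modest one.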